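Halogenated aryl variation at the saturated ring carbon

This account rests on a few compounds, and the source may have more. Where it says the series, first, only, none or still open, it means among the compounds named here.

Within the data shown here, compound 1 `CNC(=O)c1cc(Oc2ccc(C3=NNC(c4cccc(Br)c4)C3)cc2)ccn1` is the only member of the series with a number in a functional assay on MCF7 cells (Homo sapiens) for cytotoxicity, read by MTT assay, with a stated time of 72 h; a higher number here means a weaker inhibitor, a lower number a stronger inhibitor; in that assay compound 1 gives 1960 nM. Compound 2 `CNC(=O)c1cc(Oc2ccc(C3=NNC(c4ccc(Cl)c(Cl)c4)C3)cc2)ccn1`, which carries a 3,4-dichlorophenyl group on the saturated ring carbon, has no result: for compound 2 the entry reads "not determined" (no result reported). Among the measured compounds shown here, compound 1 therefore stands alone on the numbers, and no comparison between measured compounds is possible within this set.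

Compound 3 `CNC(=O)c1cc(Oc2ccc(C3=NNC(c4ccc(F)cc4)C3)cc2)ccn1` differs from compound 1 in one place: 4-fluorophenyl in place of 3-bromophenyl on a saturated ring carbon. The change exchanges one halogenated phenyl group for another on the saturated ring carbon of the five-membered non-aromatic ring with two nitrogen, leaving the shared core untouched. For the measured compounds named here, no measured pair shows how such an exchange moves the half-maximal inhibitory concentration, so the size of the step is not anchored by data. The step is expected to be modest, a 1.3-fold higher number from compound 1 to compound 3 (0.11 log units; within the scatter), with no direction that can be called beyond the scatter. Compound 3 is estimated at 2500 nM in this assay, with a range from 900 nM to 7000 nM.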

Compound 3, half-maximal inhibitory concentration: 9480 nM
The estimate for compound 3 lay 3.8-fold (0.58 log units) below the measured number; measured number above the stated range.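

Among these compounds, the exchange of 3-bromophenyl for 4-fluorophenyl on the saturated ring carbon gives the first measured step at this position in this assay (a 4.8-fold higher number from compound 1 to compound 3 (0.68 log units; beyond the scatter)). The position is therefore not indifferent to which halogenated phenyl group it carries, even though both groups count the same number of heavy atoms, with no hydrogen-bond donors or acceptors, and the shared core stays the same. No measurement at hand gives a reason for the size or direction of this step.

The halogen and its place on the phenyl group change together between compound 1 and compound 3, so this single pair cannot assign the step to either one, and a single step gives no trend across halogens. Still open, from the compounds shown here alone, is how 3-fluorophenyl, 4-bromophenyl or unsubstituted phenyl would read at this carbon, and whether a group of another kind, such as a methoxy-bearing phenyl or a pyridine ring, would be tolerated there.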